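Removing a Chloro Group from a Dichlorinated Bicyclic Scaffold

The source may hold more compounds than are shown below. What is called first, only, known or untested is meant among the compounds shown, and "the series" means these compounds.

Of the compounds shown here, two have been measured so far. Compound 1 `ClCc1cccc(Cn2cnc3c(Cl)nc(Cl)nc32)c1` and compound 2 `ClCc1cccc(Cn2cnc3nc(Cl)nc(Cl)c32)c1` share the same core and carry the same two chloro groups on it, arranged differently. In a functional assay on UACC-62 cells (Homo sapiens) for cytotoxicity, read by sulforhodamine B assay, with a stated time of 48 h (a higher number here means that more compound is tolerated, a lower number that less compound is tolerated), compound 1 gives 6450 nM, which puts it at the top of the two numbers on paper; in this assay compound 2 gives 4670 nM, and the gap to compound 1 lies within the scatter, so the two cannot be told apart.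

Compound 3 `ClCc1cccc(Cn2cnc3c(Cl)ncnc32)c1` has not yet been measured. It differs from compound 1 in a single place: hydrogen in place of chloro on an aromatic carbon. Among the measured compounds shown here, no pair among the measured compounds isolates this change, so nothing measured here speaks directly to its effect. The author therefore expects the step from compound 1 to compound 3 in this assay to be a 1.1-fold lower number from compound 1 to compound 3 (0.03 log units; within the scatter), that is, no movement beyond the scatter in either direction. For compound 3 he estimates a value of 6000 nM in this assay, with a range from 2500 nM to 14000 nM.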

Compound 3, concentration lethal to 50% of the cells: 6310 nM
Compound 3: the middle estimate sits 1.1-fold (0.02 log units) below what was measured, within the range that was stated.
By their numbers in this assay, from the lowest: compounds 2, 3 and 1 (each within the scatter of the next).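

Among the compounds shown here, the step gives the first direct reading of this change: in this assay, hydrogen in place of chloro on the aromatic carbon between two ring nitrogen atoms amounts to a 1.0-fold lower number from compound 1 to compound 3 (0.01 log units; within the scatter). The chloro group at this position can therefore leave the core without any movement beyond the scatter, so in this assay a core with one chloro group cannot be told apart from the core of compound 1, which carries two. The data offer no measurement that would explain this result.

The compounds shown leave open whether this tolerance belongs to hydrogen alone or would hold for other groups on the same carbon, such as an amine, a methoxy group or a longer chain. They also leave open what happens when the remaining chloro group, which stands meta to this position on the ring of compound 3, gives way to hydrogen or to an amine, and so whether the number in this assay depends on that group.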